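The source may report more compounds than this note shows. Statements on the series, on what has been measured and on what is new or still open speak of the compounds shown alone.

Compound 1 `CN(C)c1ccc(C#Cc2cccc(F)c2)cc1` and compound 2 `CN(C)c1ccc(C#Cc2ccc(F)cc2)cc1` share one core and differ only in where the fluoro sits. In a functional assay on LS174T cells (Homo sapiens) for antiproliferative activity, with a stated time of 4 days (a higher number here means a weaker inhibitor, a lower number a stronger inhibitor), compound 1 gives > 3000 nM, which is a limit of the assay and not a number. In this assay compound 2 likewise gives > 3000 nM, again a limit rather than a number. Both values thus rest at the limit of > 3000 nM in this assay, at which 2 of the 2 values shown sit. Compound 3 `CN(C)c1ccc(C#Cc2ccc(F)c(F)c2)cc1` differs from compound 2 by fluoro in place of hydrogen on an aromatic carbon. Within the data shown here, with only limits at hand, no measured step guides the expectation. Compound 3 is expected to stay near that limit, with an expected step that the limit leaves unreadable from compound 2 to compound 3 no larger than the usual scatter. Compound 3 is therefore estimated at 4000 nM, within 1500 nM to 12000 nM.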

Compound 3, half-maximal inhibitory concentration: > 3000 nM
Compound 3 gave a limit, no number; the forecaster's own chance of this, stated with the estimate: 75%; the middle value is on the limit's open side.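

Compound 3 also gives only a limit, so the steps from compound 1 and from compound 2 to compound 3 cannot be read. The compounds shown leave open whether the number or place of fluoro groups changes activity in this assay at all.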